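Removing the Bromo Group from the Trimethoxyphenyl Enaminone

The compounds below may be only part of what the source reports. "The series", "measured", "known", "first", "only" and "open" are said of these compounds alone.

Three compounds share a benzothiazole-bearing enaminone framework. Compound 1 `COc1cc(C(=O)/C=C\Nc2ccc(-c3nc4cc(OC)c(OC)c(OC)c4s3)cc2C)cc(OC)c1OC` gives 23300 nM in a functional assay on A549 cells (Homo sapiens) for antiproliferative activity, read by sulforhodamine B assay, with a stated time of 48 h (a lower number here means a stronger inhibitor, a higher number a weaker inhibitor), compound 2 `COc1cc(OC)c2sc(-c3ccc(N/C=C\C(=O)c4ccc(OC)c([N+](=O)[O-])c4)c(C)c3)nc2c1` gives 12100 nM in this assay, and compound 3 `COc1cc(OC)c2sc(-c3ccc(N/C=C\C(=O)c4cc(OC)c(OC)c(OC)c4Br)c(C)c3)nc2c1` gives 14000 nM in this assay. Compound 3 thus holds the second highest of the three numbers; its nearest neighbour is compound 2, within the scatter, and even the furthest, compound 1, lies within the scatter, so the three are not separable.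

Compound 4 `COc1cc(OC)c2sc(-c3ccc(N/C=C\C(=O)c4cc(OC)c(OC)c(OC)c4)c(C)c3)nc2c1` has not been measured. It differs from compound 3 in one place: hydrogen in place of bromo on an aromatic carbon. Going by the values given here, no single-point step is available among the measured compounds to calibrate this change, so the expected step is an estimate: a moderate move to a lower number, a 2.3-fold lower number from compound 3 to compound 4 (0.37 log units; beyond the scatter), somewhat beyond the scatter. Compound 4 is expected to reach 6000 nM in this assay, within 1500 nM to 25000 nM.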

Compound 4, half-maximal inhibitory concentration: 14400 nM
Beside the measured number, compound 4's estimate is 2.4-fold (0.38 log units) below it; low and high end bracket the measured number.
By their numbers in this assay, from the lowest: compounds 2, 3, 4 and 1 (each within the scatter of the next).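

In this assay, going by these compounds alone, the bromo group on this aromatic carbon, ortho to a large group, gives way to hydrogen with a 1.0-fold higher number from compound 3 to compound 4 (0.01 log units; within the scatter) and no separable effect, the first single-place reading at this position. The two other single-place steps, a 1.2-fold higher number from compound 2 to compound 4 (0.08 log units; within the scatter) for 3,4,5-trimethoxyphenyl in place of 4-methoxy-3-nitrophenyl and a 1.6-fold lower number from compound 1 to compound 4 (0.21 log units; within the scatter) for hydrogen in place of methoxy, also leave the compounds unseparated. Nothing measured here speaks to why these numbers stay together.

On these data alone, whether an amine or a carboxylic acid on this aromatic carbon would move the number beyond the scatter remains open.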